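The compounds below may be only part of what the source reports. "The series", "measured", "known", "first", "only" and "open" are said of these compounds alone.

Measured compounds:
- compound 1, `CCOC(=O)c1csc(NC(=O)[C@H](CCCCNS(N)(=O)=O)NC(=O)OCc2ccccc2)n1`: 580 nM
- compound 2, `COc1ccc(-c2csc(NC(=O)[C@H](CCCCNS(N)(=O)=O)NC(=O)OCc3ccccc3)n2)cc1`: 200 nM
- compound 3, `NS(=O)(=O)NCCCC[C@H](NC(=O)OCc1ccc(Cl)cc1)C(=O)Nc1nc(-c2ccccc2)cs1`: 530 nM

All three share one core carrying a sulfamide-bearing chain and a carbamate. In an assay for inhibition of protein deacetylase HDAC6 (Homo sapiens) (on this read-out lower numbers stand for stronger inhibition and higher numbers for weaker inhibition), compound 3 stands second highest of the three numbers; compound 1 lies within the scatter of it, while compound 2 sits beyond the scatter below both.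

Compound 4, `NS(=O)(=O)NCCCC[C@H](NC(=O)OCc1cccnc1)C(=O)Nc1nc(-c2ccccc2)cs1`, has not yet been measured. It differs from compound 3 in one place: pyridin-3-yl in place of 4-chlorophenyl on a saturated chain carbon bound to an oxygen next to a carbonyl group.

Going by the values given here, only one single-point step has been measured, a 2.9-fold lower number from compound 1 to compound 2 (0.46 log units; beyond the scatter), and it concerns a different place, on the aromatic carbon of the core rather than the carbamate. Among the compounds with values here, no measured pair separates the carbamate substituent from the rest of the molecule, so nothing measured bears directly on the change from compound 3 to compound 4. Compound 3, which already carries the chlorine on its carbamate, stands within the scatter of compound 1, which carries none, but the two also differ elsewhere, so this is not a clean comparison.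

Within the data shown here, with no direct precedent, the expectation is a step of no clear size, a 1.1-fold higher number from compound 3 to compound 4 (0.05 log units; within the scatter), that is, no change beyond the scatter. Compound 4 is therefore estimated at 600 nM in this assay, with a range from 250 nM to 1500 nM.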

Compound 4, half-maximal inhibitory concentration: 600 nM
Estimate against measurement, compound 4: no gap at the digits printed; measured number inside the range.
By their numbers in this assay, from the lowest: compound 2; then compounds 3, 1 and 4 (each within the scatter of the next).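

In this assay, going by these compounds alone, the first measured change at this place, on a saturated chain carbon bound to an oxygen next to a carbonyl group, is pyridin-3-yl in place of 4-chlorophenyl, and it gives a 1.1-fold higher number from compound 3 to compound 4 (0.05 log units; within the scatter) with no shift beyond the usual scatter. Within the data shown here, the earlier compounds could not show this, since their only clean step lay elsewhere on the molecule; here the chlorine leaves and a ring nitrogen enters, adding one hydrogen-bond acceptor by the count, yet this read-out does not separate the two aromatic rings. No measurement available here explains why this step is so small.

Among these compounds, what remains open is how far this indifference extends, since only two six-membered aromatic rings have been compared at this place, and a cyclohexyl group, a carboxylic acid or a longer chain in place of the pyridin-3-yl could still move the number. As far as these compounds go, it is also open whether the same swap would prove as small on the 4-methoxyphenyl-bearing core of compound 2, whose number stands apart from the others.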